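This account rests on a few compounds, and the source may have more. Where it says the series, first, only, none or still open, it means among the compounds named here.

Compound 1 `CCOc1c(-c2cc(OC)c(OC)c(OC)c2)oc2ccccc2c1=O`: 5400 nM
Compound 2 `CCCOc1c(-c2cc(OC)c(OC)c(OC)c2)oc2ccccc2c1=O`: 5700 nM
Compound 3 `CCCCOc1c(-c2cc(OC)c(OC)c(OC)c2)oc2ccccc2c1=O`: 8900 nM

In a functional assay on LNCaP cells (Homo sapiens) for antiproliferative activity, read by WST assay, with a stated time of 3 days (a higher number here means a weaker inhibitor, a lower number a stronger inhibitor), compound 3 gives 8900 nM and cannot be told apart from the other two compounds. Its steps from them are small (a 1.6-fold higher number from compound 2 to compound 3 (0.19 log units; within the scatter) and a 1.6-fold higher number from compound 1 to compound 3 (0.22 log units; within the scatter)). Compound 4 `CCCCCOc1c(-c2cc(OC)c(OC)c(OC)c2)oc2ccccc2c1=O` differs from compound 3 by one change (methyl in place of hydrogen on a saturated chain carbon, four bonds along the chain from an oxygen on an aromatic ring): methyl in place of hydrogen on a saturated chain carbon, four bonds along the chain from an oxygen on an aromatic ring.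

Two measured steps are of the same kind, each placing methyl on the chain one bond further out than the one before (a 1.1-fold higher number from compound 1 to compound 2 (0.02 log units; within the scatter) and a 1.6-fold higher number from compound 2 to compound 3 (0.19 log units; within the scatter)). Both stay within the scatter, so no step beyond the scatter is expected for compound 4 in this assay. The expected step is slight (a 1.1-fold higher number from compound 3 to compound 4 (0.05 log units; within the scatter)). The estimate for compound 4 is 10000 nM with 5000 nM to 20000 nM as its expected range.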

Compound 4, half-maximal inhibitory concentration: 15400 nM
Beside the measured number, compound 4's estimate is 1.5-fold (0.19 log units) below it; measured number inside the range.
By their numbers in this assay, from the lowest: compounds 1, 2, 3 and 4 (each within the scatter of the next, the first and the last beyond it).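

Adding methyl on a saturated chain carbon, four bonds along the chain from an oxygen on an aromatic ring, is a step within the scatter on its own in this assay (a 1.7-fold higher number from compound 3 to compound 4 (0.24 log units; within the scatter)), yet compound 4 is the first compound to stand clearly apart from shorter chains (a 2.7-fold higher number from compound 2 to compound 4 (0.43 log units; beyond the scatter) and a 2.9-fold higher number from compound 1 to compound 4 (0.46 log units; beyond the scatter)). Small additions that cannot be told apart one by one therefore add up to a modest weakening over the whole set. Adding ethyl gives comparable steps from two different starting chains: the same change on two cores in this assay, a 1.6-fold higher number (0.22 log units; within the scatter) from compound 1 to compound 3 and a 2.7-fold higher number (0.43 log units; beyond the scatter) from compound 2 to compound 4, 1.6-fold (0.21 log units) apart, within the scatter of two such steps.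

On these data alone, whether a still longer chain would weaken activity further remains open. So does whether a chain ending in an amine or a carboxylic acid would follow the same course at this oxygen.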